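A few compounds are considered here, and "the series" means these few. Any claim that something is new, unique, unknown or untested is made for them only; others in the source may bear on it.

Working notes on the series. In a functional assay on K562 cells (Homo sapiens), read by MTT assay, with a stated time of 72 h (a higher number here means a weaker inhibitor, a lower number a stronger inhibitor), three compounds carrying methylsulfanyl have been measured: compound 1 (`CSc1ncnc2c1c(-c1ccoc1)cn2[C@@H]1O[C@H](CO)[C@@H](O)[C@H]1O`) gives 60 nM, compound 2 (`CSc1ncnc2c1c(-c1ccsc1)cn2[C@@H]1O[C@H](CO)[C@@H](O)[C@H]1O`) gives 450 nM and compound 3 (`C#Cc1cn([C@@H]2O[C@H](CO)[C@@H](O)[C@H]2O)c2ncnc(SC)c12`) gives 30 nM. Compound 2 has the highest number of the three and is the weakest inhibitor so far. The measured gaps are a 7.5-fold higher number from compound 1 to compound 2 (0.88 log units; beyond the scatter) and a 15-fold lower number from compound 2 to compound 3 (1.18 log units; beyond the scatter), both beyond the scatter, while a 2.0-fold lower number from compound 1 to compound 3 (0.30 log units; within the scatter) stays within it.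

Compound 4 (`CN(C)c1ncnc2c1c(-c1ccsc1)cn2[C@@H]1O[C@H](CO)[C@@H](O)[C@H]1O`) keeps the thiophen-3-yl group of compound 2 and changes one other group: dimethylamino in place of methylsulfanyl on an aromatic carbon. This puts dimethylamino in place of methylsulfanyl on an aromatic carbon next to the ring nitrogen. Among the measured compounds shown here, no measured step touches this position, since all three replace the other substituent, so they bear on the change only indirectly. Compound 2 already shows, through a 15-fold lower number from compound 2 to compound 3 (1.18 log units; beyond the scatter), that one substituent swap can move the number substantially in this assay, so this change is not expected to be silent. For the measured compounds named here, the direction rests on no measured pair and remains uncertain, but a weaker inhibitor is expected. The estimated move is a 5.6-fold higher number from compound 2 to compound 4 (0.74 log units; beyond the scatter), similar in size to the modest step seen with thiophen-3-yl. For compound 4 the estimated value is 2500 nM, with an expected range of 500 nM to 12000 nM.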

Compound 4, half-maximal inhibitory concentration: 530 nM
Estimate against measurement, compound 4: 4.7-fold (0.67 log units) above; the range from low to high includes it.
By their numbers in this assay, from the lowest: compounds 3 and 1 (each within the scatter of the next); then compounds 2 and 4 (each within the scatter of the next).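

In this assay, among the compounds shown here, the first measured change at this position, dimethylamino in place of methylsulfanyl on an aromatic carbon next to the ring nitrogen, gives a 1.2-fold higher number from compound 2 to compound 4 (0.07 log units; within the scatter), so on the thiophen-3-yl background the two groups cannot be told apart. The earlier steps shown here all replaced the other substituent, where a single swap reached a 15-fold lower number from compound 2 to compound 3 (1.18 log units; beyond the scatter), whereas this one swap at this position leaves the number within the scatter, although the entering group has one more heavy atom and nitrogen takes the place of sulfur. No supporting measurement is available to account for this result.

From the compounds shown here alone, whether the same swap stays as quiet on the furan-3-yl background of compound 1 or the ethynyl background of compound 3 remains open, since this pair rests on thiophen-3-yl alone. Also open, going by these compounds, is how this position responds to groups unlike these two, such as a primary amine, a methoxy group, a longer chain such as ethylsulfanyl, or a cyclic amine such as morpholine.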